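Aryl variation at the pentyl-flanked position of the core

This account rests on a few compounds, and the source may have more. Where it says the series, first, only, none or still open, it means among the compounds named here.

Measured so far:
compound 1 `CCCCCc1c(C(C)C)nc(C(C)C)c(CO)c1-c1ccccc1NC(C)=O` — 13%
compound 2 `CCCCCc1c(C(C)C)nc(C(C)C)c(CO)c1-c1cccc(Cl)c1` — 49%
compound 3 `CCCCCc1c(C(C)C)nc(C(C)C)c(CO)c1-c1ccc(C(F)(F)F)cc1` — 35%

Three compounds share one core and differ only in the aryl group carried on the aromatic carbon opposite the ring nitrogen. In an assay on CHO cells for inhibition of Glucagon receptor (Homo sapiens), tested at 20 uM (a lower number here means less inhibition, a higher number more inhibition at the concentration tested (going by the name of the read-out)), compound 2 gives 49%, the highest of the three numbers. Compound 3 gives 35%, a number lower by a margin beyond the scatter. Compound 1 gives 13%, the furthest below compound 2, again beyond the scatter. Among these three, the chlorine-bearing phenyl ring of compound 2 stands out.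

Compound 4 `CCCCCc1c(C(C)C)nc(C(C)C)c(CO)c1-c1ccc(Cl)cc1Cl` has not been measured. It differs from compound 2 in the following way:

2,4-dichlorophenyl in place of 3-chlorophenyl on an aromatic carbon

Within the data shown here, no pair of measured compounds differing only in chlorine count or chlorine placement exists here, so the size of this step cannot be read off from the data. The step from compound 2 to compound 4 is expected to be small, a number 4 percentage points lower from compound 2 to compound 4 (within the scatter), most likely no further than the scatter and in no firm direction. Compound 4 is therefore estimated at 45%, with a range from 22% to 68%, because compound 2 at 49% is the closest measured reference.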

Compound 4, a percentage reported as inhibition, at one concentration (the size of the read-out at that concentration, not a potency): 8%
Beside the measured number, compound 4's estimate is 37 percentage points above it, outside the stated range (below it).
By their numbers in this assay, from the lowest: compounds 4 and 1 (each within the scatter of the next); then compound 3; then compound 2.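

In this assay, the aryl position opposite the ring nitrogen proves highly sensitive to the chlorine pattern: 2,4-dichlorophenyl in place of 3-chlorophenyl gives a number 41 percentage points lower from compound 2 to compound 4 (beyond the scatter) as a large step, even though both groups are chlorine-bearing phenyl rings. Chlorine on this ring therefore does not by itself go with the higher numbers, as compound 4 at 8% lies within the scatter of compound 1 at 13% despite their different aryl groups. Nothing available here bears on the reason for this step.

Still open, going by these compounds, is which part of the 2,4-dichloro pattern goes with the loss, a question that 2-chlorophenyl and 4-chlorophenyl would help to separate. Also open, on these data alone, is how a phenyl ring carrying an amine or a carboxylic acid would read at this position.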